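Benzyl in Place of Isopropyl on the Amine of Compound 1

The compounds below may be only part of what the source reports. "The series", "measured", "known", "first", "only" and "open" are said of these compounds alone.

The account concerns a functional assay on the whole organism with Mus musculus as the target; on this read-out higher numbers stand for an effect only at larger amounts of compound and lower numbers for an effect already at smaller amounts. Compound 1 `CC(C)NCc1nnc(-c2ccccc2-c2ccccc2)s1` gives 35 mg/kg in this assay. Going by the values given here, compound 2 `NCc1nnc(Cc2ccccc2)s1` is the only other measured compound, and in this assay compound 2 gives 200 mg/kg, a higher number that lies beyond the usual scatter. Among the compounds with values here, compound 1 therefore stands at the lowest of the two numbers, with compound 2 as its only neighbour.

Compound 3 `c1ccc(CNCc2nnc(-c3ccccc3-c3ccccc3)s2)cc1` has not been measured. It differs from compound 1 in one place: benzyl in place of isopropyl on an amine nitrogen. Within the data shown here, no pair of measured compounds shows this change, so nothing in the numbers says which way it will go. The change is expected to give a step of a 1.1-fold higher number from compound 1 to compound 3 (0.06 log units; within the scatter), that is, no shift beyond the scatter in either direction. Compound 3 is therefore expected to give about 40 mg/kg, within a range from 15 mg/kg to 110 mg/kg.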

Compound 3, dose for half-maximal effect: 29 mg/kg
Compound 3: middle estimate off by 1.4-fold (0.14 log units), on the high side; measured number inside the range.
By their numbers in this assay, from the lowest: compounds 3 and 1 (each within the scatter of the next); then compound 2.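

In this assay, benzyl in place of isopropyl on the amine nitrogen gives a 1.2-fold lower number from compound 1 to compound 3 (0.08 log units; within the scatter) and so produces no shift beyond the scatter. Going by these compounds alone, this is the first measured pair with a change at this position, and it shows that this nitrogen can carry a six-membered aromatic ring of carbon only, where isopropyl has no ring, with the core of compound 1 unchanged. No measurement at hand bears on why the two groups give such close numbers.

The compounds shown leave open whether a longer chain on this nitrogen, or a carboxylic acid or an amine on the benzyl ring, would also stay within the scatter. Compound 2 differs from compound 1 and compound 3 in more than one place, so its number cannot be read as the effect of any single change.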